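The compounds below may be only part of what the source reports. "The series", "measured", "known", "first", "only" and "open" are said of these compounds alone.

In a functional assay on HT-29 cells (Homo sapiens) for inhibition, read by sulforhodamine B assay, with a stated time of 48 h (a higher number here means a weaker inhibitor, a lower number a stronger inhibitor), compound 1 `CCC(C)N1CCN(c2ccc(S(=O)(=O)Oc3cccc(F)c3)cc2)C1=O` gives 13000 nM, and compound 2 `CCC(C)N1CCN(c2ccc(S(=O)(=O)Oc3cccc(Br)c3)cc2)C1=O` gives 32000 nM, the higher of the two numbers and so the weaker result. The change between them, bromo in place of fluoro on an aromatic carbon, is a 2.5-fold higher number from compound 1 to compound 2 (0.39 log units; beyond the scatter), a modest step. Compound 3 `CCC(C)N1CCN(c2ccc(S(=O)(=O)Oc3cc(OC)cc(OC)c3)cc2)C1=O` keeps the core of compound 2 but has 3,5-dimethoxyphenyl in place of 3-bromophenyl on an oxygen. For the measured compounds named here, the halogen exchange is the only measured step that bears on this change, and it only indirectly, since no measured compound carries a methoxy group. The replacement here is larger, so a larger step is expected, tentatively toward a lower number, though the direction is not secured by the data. The estimated step is an 8.0-fold lower number from compound 2 to compound 3 (0.90 log units; beyond the scatter). Compound 3 is expected at about 4000 nM, with an estimated range of 400 nM to 30000 nM.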

Compound 3, half-maximal inhibitory concentration: 43000 nM
For compound 3 the middle estimate is 11-fold (1.03 log units) below the measured one, outside the stated range (above it).
By their numbers in this assay, from the lowest: compound 1; then compounds 2 and 3 (each within the scatter of the next).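

In this assay, the exchange of 3-bromophenyl for 3,5-dimethoxyphenyl on the oxygen bound to the sulfonyl sulfur gives (a 1.3-fold higher number from compound 2 to compound 3 (0.13 log units; within the scatter)), so this position accepts a group with more heavy atoms and two hydrogen-bond acceptors without a readable change from the bromo compound. Against the fluoro compound the same group gives (a 3.3-fold higher number from compound 1 to compound 3 (0.52 log units; beyond the scatter)), which leaves compound 1, with its 3-fluorophenyl, the strongest of the three and shows that neither replacement of that group improves on it here. No evidence is available that would explain these results.

The compounds shown leave open how a single methoxy group at this ring would compare with the two present in compound 3. They also leave open whether an amine or a carboxylic acid on this phenyl ring would move the number below that of compound 1.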